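Replacing the Thiazolyl Group of Compound 2

The compounds below may be only part of what the source reports. "The series", "measured", "known", "first", "only" and "open" are said of these compounds alone.

In an ADME assay on a cell-free system (plasma, Homo sapiens) for protein binding, read by LC-MS, using equilibrium dialysis, with a stated time of 4 h (a lower number here means a smaller unbound share, a higher number a larger unbound share of the compound), compound 2 (`Cn1ccc2c(Cc3ccc(-c4nccs4)cc3)cc(C(=O)N[C@@H]3CCOC[C@H]3O)nc21`) gives 0.02 and sits within the scatter of compound 1 (`Cn1cc(-c2ccc(Cc3cc(C(=O)NC4CCOCC4)nc4c3ccn4C)cn2)cn1`) at 0.04 on that scale. Compound 3 (`Cn1ccc(-c2ccc(Cc3cc(C(=O)N[C@@H]4CCCC[C@H]4O)nc4c3ccn4C)cn2)n1`) gives 0.12 and stands clear of compound 2 by more than the scatter, with a larger unbound share.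

Compound 4 (`Cn1ccc(-c2ccc(Cc3cc(C(=O)N[C@@H]4CCOC[C@H]4O)nc4c3ccn4C)cc2)n1`) has not yet been measured in this assay. It departs from compound 2 in one place, on an aromatic carbon of a six-membered aromatic ring of carbon only, para to a large group, where 1-methyl-1H-pyrazol-3-yl stands in place of 1,3-thiazol-2-yl (1-methyl-1H-pyrazol-3-yl in place of 1,3-thiazol-2-yl on an aromatic carbon).

Among the measured compounds shown here, no measured pair isolates this change, so the data give no direct size for the step. Compound 3 also carries the 1-methyl-1H-pyrazol-3-yl group and gives 0.12 in this assay, but it differs from compound 4 elsewhere too, which makes it only weak support for a slight upward lean. A small rise is therefore expected (a 1.5-fold higher number from compound 2 to compound 4 (0.18 log units; within the scatter)) and would stay within the scatter. For compound 4 the estimated unbound fraction is 0.03 with an expected range from 0.015 to 0.06 in this measurement.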

Compound 4, unbound fraction: 0.02
For compound 4 the middle estimate is 1.5-fold (0.18 log units) above the measured one; the range from low to high includes it.
By their numbers in this assay, from the lowest: compounds 2, 4 and 1 (each within the scatter of the next); then compound 3.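

In this assay, the exchange of 1,3-thiazol-2-yl for 1-methyl-1H-pyrazol-3-yl on an aromatic carbon of a six-membered aromatic ring of carbon only, para to a large group, now has a measured size, with no change at the digits printed from compound 2 to compound 4 (within the scatter). At this position, then, one five-membered aromatic ring with 2 hetero atoms gave way to another, with sulfur leaving and one more heavy atom entering, and the unbound fraction stayed within the scatter. No measurement shown here offers a reason for this result.

The compounds shown leave open whether a group of another kind at this position, such as a morpholine, a carboxylic acid or a longer alkyl chain, would also stay within the scatter of compound 2. This single pair also cannot say whether the same exchange would give a step of the same size on a compound that differs elsewhere from compound 2, so it sets no general rule for the group.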